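The source may hold more compounds than are shown below. What is called first, only, known or untested is meant among the compounds shown, and "the series" means these compounds.

Measured so far:
- compound 1, `CNC(=O)c1cc(C(=O)NC2CC2)cn(Cc2ccc(C)cc2)c1=O`: 3.5
- compound 2, `CNC(=O)c1cc(C(=O)NCCO)cn(Cc2ccccc2)c1=O`: 1.9

In a physicochemical assay for lipophilicity, at pH 7.4 (on this read-out higher numbers stand for higher lipophilicity and lower numbers for lower lipophilicity), compound 1 gives 3.5, the higher of the two numbers recorded; the nearest is compound 2, whose value in this assay is 1.9, a gap that lies beyond the usual scatter. Within the data shown here, no pair of measured compounds differing in one place is available, so no single-change step has been seen.

Compound 3, `CNC(=O)c1cc(C(=O)NC2CC2)cn(Cc2cccc3occc23)c1=O`, has not been measured in this assay. It differs from compound 1 as follows: 1-benzofuran-4-yl in place of 4-methylphenyl on a saturated chain carbon bound to an aromatic nitrogen. Among the measured compounds shown here, with no measured step of comparable kind to lean on, the expectation rests on the value of compound 1 alone, and a step no larger than the scatter is expected, with no firm direction; the change from compound 1 to compound 3 is estimated at a number 0.10 log units lower from compound 1 to compound 3 (within the scatter). Compound 3 is therefore expected to give about 3.4 in this assay, within a range of 2.9 to 3.9.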

Compound 3, distribution coefficient: 3.4
Compound 3: the middle estimate sits on the measured number at the digits printed; measured number inside the range.
By their numbers in this assay, from the lowest: compound 2; then compounds 3 and 1 (each within the scatter of the next).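

In this assay, among these compounds, the first single-place change reads a number 0.10 log units lower from compound 1 to compound 3 (within the scatter). At this position, on a saturated chain carbon bound to an aromatic nitrogen, 1-benzofuran-4-yl thus stands in place of 4-methylphenyl with no difference beyond the scatter, even though the entering group adds a five-membered aromatic ring with 1 hetero atom. No measured evidence bears on the reason for this result.

On these data alone, whether the same holds for a group carrying an amine or a carboxylic acid at this place remains open, as does the effect of a longer chain there. As far as these compounds go, compound 2 differs from compound 1 in more than one place, so the separate contributions of those differences also remain open.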